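From Ethoxycarbonyl to Acetyl on a Shared Core

This account rests on a few compounds, and the source may have more. Where it says the series, first, only, none or still open, it means among the compounds named here.

Three measured compounds share one core and differ only in the group on a carbonyl carbon. Compound 1 `COc1ccc2c(c1)OC(c1cc(OC)c(OC)c(OC)c1)C(C(=O)NC(C)(C)C)=C2` carries a tert-butyl amide; in a functional assay for inhibition of nuclear factor NF-kappa-B complex (Homo sapiens) (on this read-out lower numbers stand for stronger inhibition and higher numbers for weaker inhibition), compound 1 gives 28400 nM. Compound 2 `COc1ccc2c(c1)OC(c1cc(OC)c(OC)c(OC)c1)C(C(=O)O)=C2` carries the free acid; in this assay compound 2 reaches only the limit of the assay, > 50000 nM. Compound 3 `CCOC(=O)C1=Cc2ccc(OC)cc2OC1c1cc(OC)c(OC)c(OC)c1` carries the ethyl ester; in this assay compound 3 gives 25000 nM, the lowest of the two actual numbers, with compound 1 nearest, since a 1.1-fold lower number from compound 1 to compound 3 (0.06 log units; within the scatter). The other two steps, an at least 1.7-fold higher number from compound 1 to compound 2 (0.24 log units; that floor lies within the scatter) and an at least 2.0-fold lower number from compound 2 to compound 3 (0.30 log units; that floor lies within the scatter), only place the acid at the limit of > 50000 nM in this assay, at which 1 of the 3 values shown sits, while amide and ester sit together.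

Compound 4 `COc1ccc2c(c1)OC(c1cc(OC)c(OC)c(OC)c1)C(C(C)=O)=C2` is the next analogue, and its difference from compound 3 is methyl in place of ethoxy on a carbonyl carbon. Within the data shown here, the one step that bears on it, the swap of the amide for the ester, stayed within the scatter, so a neutral group on the carbonyl carbon has so far made little difference; only the acid of compound 2 broke that pattern. Compound 4 is therefore expected to give about 30000 nM in this assay, between 10000 nM and 90000 nM. This estimate means a 1.2-fold higher number from compound 3 to compound 4 (0.08 log units; within the scatter), a step expected to stay within the scatter.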

Compound 4, half-maximal inhibitory concentration: 14100 nM
The estimate for compound 4 lay 2.1-fold (0.33 log units) above the measured number; the range from low to high includes it.
By their numbers in this assay, from the lowest: compounds 4, 3 and 1 (each within the scatter of the next). At a limit, above all of these: compound 2.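

Among these compounds, with methyl on the carbonyl carbon, this position carries a group joined through carbon rather than through oxygen or nitrogen for the first time, and the groups with no net charge still stay together: the exchange for ethoxy gives a 1.8-fold lower number from compound 3 to compound 4 (0.25 log units; within the scatter), and the exchange for (tert-butyl)amino gives a 2.0-fold lower number from compound 1 to compound 4 (0.30 log units; within the scatter). Set against the free acid, the same methyl gives an at least 3.5-fold lower number from compound 2 to compound 4 (0.54 log units; beyond the scatter), the first step at this position printed as beyond the scatter, although its size is only a floor. Compound 2 remains a limit and not a number: the limit of > 50000 nM in this assay, at which 1 of the 4 values shown sits.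

The compounds shown leave open whether a longer chain in place of the methyl, such as ethyl or propyl, or an aminomethyl group, would separate from compound 1, compound 3 and compound 4 beyond the scatter in this assay. They also leave open whether a nitrile or a primary amide in place of the whole acetyl group would stay with these three compounds or fall with the free acid.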